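Working notes: methoxy to fluoro on the acid core

The compounds below may be only part of what the source reports. "The series", "measured", "known", "first", "only" and "open" are said of these compounds alone.

Measured so far, all in a functional assay, with a stated time of 150 min, tested at 20 ug/mL; a higher number here means a stronger effect of the compound at the concentration tested, a lower number a weaker effect:
compound 1, `COC(=O)c1c(Nc2ccc(OC)cc2)sc(C(=O)c2ccc(OC)cc2)c1C`, gives 12%
compound 2, `COC(=O)c1c(Nc2ccc(F)cc2)sc(C(=O)c2ccc(OC)cc2)c1C`, gives 18.2%
compound 3, `COc1ccc(Nc2sc(C(=O)c3ccc(OC)cc3)c(C)c2C(=O)O)cc1`, gives 32.5%

Compound 2 differs from compound 1 by one change, (fluoro in place of methoxy on an aromatic carbon). The step belonging to it is a number 6.2 percentage points higher from compound 1 to compound 2 (within the scatter), so on the core of compound 1 this change makes no difference that can be separated from the scatter.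

Compound 3 differs from compound 1 at the core, (hydrogen in place of methyl on an oxygen next to a carbonyl group). Here the step is a number 20.5 percentage points higher from compound 1 to compound 3 (beyond the scatter). For the measured compounds named here, compound 3 stands highest of the three, beyond the scatter against both compound 1 and compound 2; compound 2 and compound 3 have no direct step between them, and their two values alone show compound 3 the higher one.

Compound 4, `COc1ccc(C(=O)c2sc(Nc3ccc(F)cc3)c(C(=O)O)c2C)cc1`, is not yet measured in this assay. It differs from compound 3 by fluoro in place of methoxy on an aromatic carbon. Going by the values given here, this is the same change as the one from compound 1 to compound 2, the place being identical in both cases; what differs is the core, told by hydrogen in place of methyl on an oxygen next to a carbonyl group. Among the compounds with values here, the only guide is therefore the single earlier step, which lies within the scatter. The step from compound 3 to compound 4 is expected to be of the same small size, a number 5.5 percentage points higher from compound 3 to compound 4 (within the scatter). For compound 4 the estimate is 38%, with an expected range from 24% to 52%, the width reflecting that transfer of a within-scatter step across a core change rests on one pair alone.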

Compound 4, a percentage reported as activity, at one concentration (the size of the read-out at that concentration, not a potency): 3.58%
Estimate against measurement, compound 4: 34.4 percentage points above, and the stated range ends above it.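

In this assay, fluoro in place of methoxy does not carry over from the core of compound 1 to the core of compound 3, since on the latter the change gives a number 28.9 percentage points lower from compound 3 to compound 4 (beyond the scatter), and the two steps differ: the same change on two cores in this assay, a number 6.2 percentage points higher (within the scatter) from compound 1 to compound 2 and a number 28.9 percentage points lower (beyond the scatter) from compound 3 to compound 4, 35.1 percentage points apart, beyond the scatter of two such steps

Read the other way, hydrogen in place of methyl on the core also depends on what the aromatic ring carries, giving a number 14.6 percentage points lower from compound 2 to compound 4 (beyond the scatter) with fluoro present, against the step seen with methoxy present: the same change on two cores in this assay, a number 20.5 percentage points higher (beyond the scatter) from compound 1 to compound 3 and a number 14.6 percentage points lower (beyond the scatter) from compound 2 to compound 4, 35.1 percentage points apart, beyond the scatter of two such steps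

Both readings rest on the same four compounds, so they are one observation: in this set the two changes do not add up, and a step measured on one core is a poor guide to the other, but this does not show why, and a single pair per core gives no rule for other groups or other cores.

Still open, as far as these compounds go, is whether the low value of compound 4 is specific to fluoro or follows from losing methoxy on this core, which a chloro, a methyl or a plain hydrogen at the same place would help to separate. Also open, from the compounds shown here alone, is whether the dependence on the core persists with a primary amide in place of the carboxylic acid, and all of this is a read-out at one concentration rather than a potency.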